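The source may hold more compounds than are shown below. What is called first, only, known or untested is meant among the compounds shown, and "the series" means these compounds.

Compound 2 `COc1cc(-c2nn(-c3cccc(NC(=O)Nc4cccc(C(F)(F)F)c4)c3)cc2-c2ccncc2)ccc1Cl` is one of three members of a small series tested in a functional assay on LOX IMVI cells (Homo sapiens) for inhibition, read by sulforhodamine B assay, with a stated time of 48 h (on this read-out higher numbers stand for lower toxicity in this test and lower numbers for higher toxicity in this test), where compound 2 gives 3460 nM. Among the two numbers available, compound 2 stands highest; its nearest neighbour is compound 1 `O=C(Nc1cccc(-n2cc(-c3ccncc3)c(-c3ccc(Cl)c(O)c3)n2)c1)Nc1cc(C(F)(F)F)cc(C(F)(F)F)c1`, which in this assay gives 2750 nM, within the scatter of compound 2. Compound 3 `COc1cc(-c2nn(-c3cccc(NC(=O)Nc4ccc(Cl)c(Cl)c4)c3)cc2-c2ccncc2)ccc1Cl` returns only a limit in this assay, > 50000 nM. For the measured compounds named here, the one measured step, an at least 14-fold higher number from compound 2 to compound 3 (1.15 log units; beyond the scatter), pushes the number to that limit, as recorded by the limit of > 50000 nM in this assay, at which 1 of the 3 values shown sits.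

Compound 4 `COc1cc(-c2nn(-c3cccc(NC(=O)Nc4cc(C(F)(F)F)cc(C(F)(F)F)c4)c3)cc2-c2ccncc2)ccc1Cl` differs from compound 2 by trifluoromethyl in place of hydrogen on an aromatic carbon. Going by the values given here, no measured step touches this change: the single step recorded swaps one aryl group for another, not a hydrogen for a trifluoromethyl. The values of compound 1 and compound 2 sit within the scatter of each other, which suggests this assay is not very sensitive to changes around the aryl end of the molecule. Compound 4 is therefore expected to move by no more than the scatter, a 1.2-fold lower number from compound 2 to compound 4 (0.06 log units; within the scatter), giving an estimated 3000 nM within 1000 nM to 10000 nM.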

Compound 4, concentration lethal to 50% of the cells: 2940 nM
Compound 4: the middle estimate sits 1.0-fold (0.01 log units) above what was measured; the measured number falls inside the stated range.
By their numbers in this assay, from the lowest: compounds 1, 4 and 2 (each within the scatter of the next). At a limit, above all of these: compound 3.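

In this assay, neither trifluoromethyl in place of hydrogen on this aromatic carbon, meta to a trifluoromethyl group (a 1.2-fold lower number from compound 2 to compound 4 (0.07 log units; within the scatter)), nor methyl in place of hydrogen on an oxygen on an aromatic ring (a 1.1-fold higher number from compound 1 to compound 4 (0.03 log units; within the scatter)) separates the compounds compared. Neither step approaches the one from the 3,4-dichlorophenyl swap, which ends at a limit (an at least 14-fold higher number from compound 2 to compound 3 (1.15 log units; beyond the scatter)). What is shown gives no measured reason for the small size of these two steps.

Going by these compounds, it remains open whether a nitrile or an amine on this aromatic carbon would stay as close to compound 2. On these data alone, it is also open whether a longer chain in place of the methyl on the oxygen of compound 4 would stay as close to that compound.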